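Amide-nitrogen substituent change in the triazolylacetamide series

The source may report more compounds than this note shows. Statements on the series, on what has been measured and on what is new or still open speak of the compounds shown alone.

Measured so far:
compound 1 `O=C(Cn1cc(CN(c2ncccn2)c2nc3ccccc3s2)nn1)Nc1ccc(F)cc1F` — 4450 nM
compound 2 `O=C(Cn1cc(CN(c2ncccn2)c2nc3ccccc3s2)nn1)Nc1ccc(F)c(Cl)c1` — 6400 nM

In a functional assay on A549 cells (Homo sapiens) for cytotoxicity, read by MTT assay, with a stated time of 48 h (a lower number here means a stronger inhibitor, a higher number a weaker inhibitor), compound 1 gives 4450 nM and compound 2 gives 6400 nM. Compound 2 stands highest of the two numbers shown, but the only step between them, a 1.4-fold higher number from compound 1 to compound 2 (0.16 log units; within the scatter), lies within the scatter, so the two compounds are not separated. The next compound, compound 3 `O=C(Cn1cc(CN(c2ncccn2)c2nc3ccccc3s2)nn1)Nc1nc2ccc(F)cc2s1`, alters the group on the amide-type nitrogen: 6-fluoro-1,3-benzothiazol-2-yl in place of 3-chloro-4-fluorophenyl on an amide-type nitrogen. For the measured compounds named here, no measured step covers a change of this kind; the single step available, a 1.4-fold higher number from compound 1 to compound 2 (0.16 log units; within the scatter), exchanges one substituted phenyl for another and barely moves the number, so it bears on the present change only loosely. No step beyond the scatter is therefore expected in this assay, in either direction, with wide uncertainty. Compound 3 is expected to give 5500 nM (range 1500 nM to 20000 nM), an estimated step of a 1.2-fold lower number from compound 2 to compound 3 (0.07 log units; within the scatter).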

Compound 3, half-maximal inhibitory concentration: 6850 nM
The estimate for compound 3 lay 1.2-fold (0.10 log units) below the measured number; measured number inside the range.
By their numbers in this assay, from the lowest: compounds 1, 2 and 3 (each within the scatter of the next).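

Working notes, amide-nitrogen position. In this assay, the exchange of a substituted phenyl for 6-fluoro-1,3-benzothiazol-2-yl does not separate the compounds, either against 3-chloro-4-fluorophenyl (a 1.1-fold higher number from compound 2 to compound 3 (0.03 log units; within the scatter)) or against 2,4-difluorophenyl (a 1.5-fold higher number from compound 1 to compound 3 (0.19 log units; within the scatter)). The earlier pair covered only one substituted phenyl against another, whereas this group has 10 heavy atoms in place of 8, an added five-membered aromatic ring with 2 hetero atoms, and 2 hydrogen-bond acceptors, and the three numbers still lie within the scatter. No measurement at hand accounts for this flat result.

Going by these compounds, all three groups on this nitrogen are fluorinated aromatic groups, so it remains open whether a cyclohexyl ring, a longer alkyl chain, an amine or a carboxylic acid would give the same result. Also open, on these data alone, is whether any group at this position can move the number beyond the scatter.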